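Methyl in Place of Methoxy: Expectation for Compound 3

The compounds below may be only part of what the source reports. "The series", "measured", "known", "first", "only" and "open" are said of these compounds alone.

Measured compounds:
compound 1, `COc1ccccc1OCC1SCCN1C(=O)CSC(C)=O`: 17 mg/kg
compound 2, `COc1ccc(OCC2SCCN2C(=O)CSC(C)=O)cc1`: 19 mg/kg

In a functional assay on the whole organism for inhibition, with Cavia porcellus as the target (on this read-out lower numbers stand for an effect already at smaller amounts and higher numbers for an effect only at larger amounts of compound), compound 1 gives 17 mg/kg, and compound 2 gives 19 mg/kg. Compound 1 shows the nominally lower of the two numbers, but the gap to compound 2 lies within the scatter of repeated measurements, so the two compounds cannot be told apart on these data. Within the data shown here, no pair of measured compounds differs in a single place, so no measured step is available for comparison.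

Compound 3, `CC(=O)SCC(=O)N1CCSC1COc1ccccc1C`, differs from compound 1 by methyl in place of methoxy on an aromatic carbon. Among the measured compounds shown here, with no measured step of this kind to lean on, the expected step in this assay is a 1.2-fold higher number from compound 1 to compound 3 (0.07 log units; within the scatter), that is, no change beyond the scatter in either direction. Compound 3 is therefore estimated to give 20 mg/kg in this assay, with a range from 8 mg/kg to 50 mg/kg.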

Compound 3, dose for half-maximal effect: 29 mg/kg
Compound 3: middle estimate off by 1.5-fold (0.16 log units), on the low side; low and high end bracket the measured number.
By their numbers in this assay, from the lowest: compounds 1, 2 and 3 (each within the scatter of the next).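

In this assay, among these compounds, methyl in place of methoxy on an aromatic carbon, ortho to a large group, gives a 1.7-fold higher number from compound 1 to compound 3 (0.23 log units; within the scatter), and this is the first step measured at this position. The swap removes one heavy atom and the hydrogen-bond acceptor of methoxy, yet the effect in the whole organism remains, and the two compounds cannot be told apart on these data. No measurement of any property of these groups bears on this step, so the data offer no explanation for it.

From the compounds shown here alone, whether a larger or charged group at this place, such as an amine, a carboxylic acid or a longer chain, would move the number beyond the scatter stays open. The compounds shown also leave open whether the same change on compound 2 would give a similar step.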